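Fluoro-to-hydrogen step across two cores of a plasma-active series

A few compounds are considered here, and "the series" means these few. Any claim that something is new, unique, unknown or untested is made for them only; others in the source may bear on it.

The series shares a chloro-substituted benzylamide carrying a tetrazole and an amide-linked pyrazoline or bicyclic core acylated by an alpha-hydroxy arylacetyl group. Compound 1 `O=C(NCc1cc(Cl)ccc1-n1cnnn1)[C@@H]1CC=NN1C(=O)[C@H](O)c1ccccc1F` and compound 2 `O=C(NCc1cc(Cl)ccc1-n1cnnn1)[C@@H]1CC=NN1C(=O)[C@H](O)c1ccccc1` carry the pyrazoline core. In a functional assay on a cell-free system (plasma, Homo sapiens), with a stated time of 3 min (a higher number here means a weaker inhibitor, a lower number a stronger inhibitor), compound 1 gives 1100 nM, and compound 2 gives 840 nM. The change between them is hydrogen in place of fluoro on an aromatic carbon and it produced a 1.3-fold lower number from compound 1 to compound 2 (0.12 log units; within the scatter).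

Compound 3 `O=C(NCc1cc(Cl)ccc1-n1cnnn1)[C@@H]1C[C@@H]2C[C@@H]2N1C(=O)[C@H](O)c1ccccc1F` carries the bicyclic core; in this assay compound 3 gives 770 nM. The difference between the core of compound 3 and the core of compound 1 is not broken down here. For the measured compounds named here, all three values so far lie within the scatter of one another.

Compound 4 `O=C(NCc1cc(Cl)ccc1-n1cnnn1)[C@@H]1C[C@@H]2C[C@@H]2N1C(=O)[C@H](O)c1ccccc1` is not yet measured. It differs from compound 3 by hydrogen in place of fluoro on an aromatic carbon, the same change as that from compound 1 to compound 2, at the same place. For compound 4 in this assay a step of a 1.2-fold lower number from compound 3 to compound 4 (0.07 log units; within the scatter) is expected, because the earlier 1.3-fold lower number from compound 1 to compound 2 (0.12 log units; within the scatter) was small and within the scatter. The estimate for compound 4 is therefore 650 nM, with a range from 350 nM to 1200 nM.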

Compound 4, half-maximal inhibitory concentration: 620 nM
The estimate for compound 4 lay 1.0-fold (0.02 log units) above the measured number, and the stated range covers the measured number.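

In this assay, hydrogen in place of fluoro on the second core gives a 1.2-fold lower number from compound 3 to compound 4 (0.09 log units; within the scatter), and the two steps can be set side by side: the same change on two cores in this assay, a 1.3-fold lower number (0.12 log units; within the scatter) from compound 1 to compound 2 and a 1.2-fold lower number (0.09 log units; within the scatter) from compound 3 to compound 4, 1.1-fold (0.02 log units) apart, within the scatter of two such steps. Within these two pairs, the 2-fluorophenyl to phenyl change therefore carries from one core to the other with no detectable difference in its size. This does not show that the change has a real effect on either core, since each step lies within the scatter, and two cores in a single assay give no basis for a rule across the series.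

The compounds shown leave open whether a methoxy group, a trifluoromethyl group, an amine or a carboxylic acid at the same place would move the number beyond the scatter, and whether such a step would then match on both cores. They also leave open how the change behaves when the hydroxy group of the acyl part is replaced by an amine.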